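The source may report more compounds than this note shows. Statements on the series, on what has been measured and on what is new or still open speak of the compounds shown alone.

Compound 1 `C(=C/c1nc(Nc2ccccc2)c2sccc2n1)\c1ccccc1`: in a functional assay on L02 cells (Homo sapiens) for inhibition, read by Griess assay, with stated times of 1 h and 24 h (a higher number here means a weaker inhibitor, a lower number a stronger inhibitor), compound 1 gives only a limit, > 1000000 nM. Compound 2 `CN(c1ccccc1)c1nc(/C=C/c2ccccc2)nc2ccsc12`: in this assay compound 2 likewise gives only a limit, > 1000000 nM. Compound 3 `COc1cc(/C=C/c2nc(N(C)C)c3sccc3n2)cc(OC)c1OC`: in this assay compound 3 also gives only a limit, > 1000000 nM.

Compound 3 thus stands at the same limit as the other two, with no number that would rank it. Compound 4 `COc1cc(/C=C/c2nc(Nc3ccc(C)cc3)c3sccc3n2)cc(OC)c1OC` differs from it in one place: (4-methylphenyl)amino in place of dimethylamino on an aromatic carbon. For the measured compounds named here, the only single-place step measured, a step that the two limits leave unreadable from compound 1 to compound 2, is unreadable, since both of its ends sit at the limit described in the limit of > 1000000 nM in this assay, at which 3 of the 3 values shown sit. Going by the values given here, no measured step therefore tells the size or direction of the change from compound 3 to compound 4, and another result at the limit is the most likely outcome. The expected step is a step that the limit leaves unreadable from compound 3 to compound 4, essentially none. Compound 4 is estimated at 2000000 nM, with a range from 300000 nM to 10000000 nM.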

Compound 4, half-maximal inhibitory concentration: < 40000 nM
Compound 4: no number, only a limit (the forecaster's own chance of this, stated with the estimate: 80%); middle value at least 50-fold (1.69 log units) from the limit.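

In this assay, (4-methylphenyl)amino in place of dimethylamino on this aromatic carbon gives an at least 25-fold lower number from compound 3 to compound 4 (1.39 log units; beyond the scatter), the first step among these compounds that can be read. This shows that the group on this carbon can move a compound away from the upper limit when the rest of the structure stays the same. The result for compound 4, < 40000 nM, is itself a limit and not a number.

On these data alone, the step changes the ring, its methyl and the amino hydrogen together, so which of these matters remains open. As far as these compounds go, how a morpholine or a benzylamino group would behave on this carbon also remains open.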